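Swapping Fluoro for Chloro on Compound 3

The source may report more compounds than this note shows. Statements on the series, on what has been measured and on what is new or still open speak of the compounds shown alone.

In an ADME assay on Vero cells (Chlorocebus sabaeus) for cytotoxicity, read by CellTiter-Glo, with a stated time of 72 h (a higher number here means that more compound is tolerated, a lower number that less compound is tolerated), compound 1 `[O-][n+]1nc(NC2CCC2)[n+]([O-])c2ccc(F)cc21` reads 1.6 ug/mL and compound 2 `[O-][n+]1nc(NC2CCCC2)[n+]([O-])c2ccc(F)cc21` reads 2.3 ug/mL while compound 3 `COCC(C)Nc1n[n+]([O-])c2cc(F)ccc2[n+]1[O-]` stands highest of the three at 6.3 ug/mL on this scale. Compound 4 `COCC(C)Nc1n[n+]([O-])c2cc(Cl)ccc2[n+]1[O-]` differs from compound 3 only by chloro in place of fluoro on an aromatic carbon. For the measured compounds named here, no measured step touches that carbon. The steps in hand change only the group on the nitrogen: a 1.4-fold higher number from compound 1 to compound 2 (0.16 log units; within the scatter) and a 3.9-fold higher number from compound 1 to compound 3 (0.60 log units; beyond the scatter) and also a 2.7-fold higher number from compound 2 to compound 3 (0.44 log units; beyond the scatter) as the last of them. They offer only a rough scale, so no step beyond the scatter is expected in this assay here. The expected move is a 1.3-fold lower number from compound 3 to compound 4 (0.10 log units; within the scatter) as a small estimated change. For compound 4 the estimated value is 5 ug/mL with an expected range from 2.2 ug/mL to 11 ug/mL in this assay.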

Compound 4, half-maximal cytotoxic concentration: 2.6 ug/mL
Beside the measured number, compound 4's estimate is 1.9-fold (0.28 log units) above it; measured number inside the range.
By their numbers in this assay, from the lowest: compounds 1, 2 and 4 (each within the scatter of the next); then compound 3.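

In this assay, the aromatic carbon carrying the halogen turns out to matter: chloro in place of fluoro gives a 2.4-fold lower number from compound 3 to compound 4 (0.38 log units; beyond the scatter), so less compound is tolerated. For the compounds shown here, the earlier steps changed only the group on the nitrogen, so this is the first sign that a change on the ring can also shift the number beyond the scatter. Nothing available explains why this swap lowers the number.

On these data alone, it remains open how a bromo or a nitrile on that carbon would read. As far as these compounds go, the same swap on the cyclobutyl or cyclopentyl compounds also remains untested here.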